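The source may hold more compounds than are shown below. What is called first, only, known or untested is meant among the compounds shown, and "the series" means these compounds.

The series shares the core of compound 1 `O=c1oc2ccccc2c2nc3c(ccc4cc[nH]c43)c(-c3ccc(C(F)(F)F)cc3)c12` and varies one group on an aromatic carbon. In a functional assay on B16-F10 cells (Mus musculus) for cytotoxicity (on this read-out higher numbers stand for weaker inhibition and lower numbers for stronger inhibition), compound 1 gives 70700 nM as its reading. Compound 2 `O=c1oc2ccccc2c2nc3c(ccc4cc[nH]c43)c(-c3cccc4ccccc34)c12` gives 70700 nM as its reading. Compound 3 `O=c1oc2ccccc2c2nc3c(ccc4cc[nH]c43)c(-c3c(Cl)cccc3Cl)c12` gives 70700 nM and so stands level with both at the digits shown.

Compound 4 `O=c1oc2ccccc2c2nc3c(ccc4cc[nH]c43)c(-c3ccc(O)cc3)c12` is still unmeasured. Its change from compound 3 is 4-hydroxyphenyl in place of 2,6-dichlorophenyl on an aromatic carbon with 4-hydroxyphenyl in place of 2,6-dichlorophenyl on an aromatic carbon, opposite the ring nitrogen.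

Three swaps at that carbon bear on it, namely no change at the digits printed from compound 1 to compound 2 (within the scatter) and also no change at the digits printed from compound 1 to compound 3 (within the scatter) and also no change at the digits printed from compound 2 to compound 3 (within the scatter) with none of them beyond the scatter. Within the data shown here, no measured compound carries the 4-hydroxyphenyl group, so this entry is untested. Going by these compounds, on the strength of no change at the digits printed from compound 1 to compound 3 (within the scatter) no step beyond the scatter is expected in this assay for compound 4, though a move toward stronger inhibition stays open.

The expected step is a 1.2-fold lower number from compound 3 to compound 4 (0.07 log units; within the scatter) on this estimate. For compound 4 the estimated value is 60000 nM with an expected range from 20000 nM to 80000 nM in this assay.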

Compound 4, half-maximal inhibitory concentration: 70700 nM
Estimate against measurement, compound 4: 1.2-fold (0.07 log units) below; measured number inside the range.
By their numbers in this assay, from the lowest: compounds 1, 2, 3 and 4 (each within the scatter of the next).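

In this assay, the 4-hydroxyphenyl group brings 1 hydrogen-bond donor and 1 hydrogen-bond acceptor to this carbon opposite the ring nitrogen, where 2,6-dichlorophenyl has 0 of each, and the result is no change at the digits printed from compound 3 to compound 4 (within the scatter). The comparison with the fused naphthalen-1-yl entry reads the same, with no change at the digits printed from compound 2 to compound 4 (within the scatter), and hydroxy in place of trifluoromethyl on the same phenyl ring gives no change at the digits printed from compound 1 to compound 4 (within the scatter). The flat readings at this position therefore now extend to a phenyl group bearing a hydroxy, and no supporting data bear on what lies behind this result.

Going by these compounds, with one printed reading across all four compounds, it remains open whether any group at this carbon can shift the number. An amine or carboxylic acid on the phenyl ring, or a longer chain at this carbon, would test that.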